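This account rests on a few compounds, and the source may have more. Where it says the series, first, only, none or still open, it means among the compounds named here.

Compound 1 `CCCCCCCCCCCC[C@@H](O)[C@H]1CC[C@H]([C@H](O)CCCCCCCCCCNC(=O)c2ccco2)O1`: 100000 nM
Compound 2 `CCCCCCCCCCCC[C@@H](O)[C@H]1CC[C@H]([C@H](O)CCCCCCCCCCNC(=O)c2cncs2)O1`: 100000 nM

In a functional assay on St-4 cells (Homo sapiens) for inhibition, read by colorimetric assay and sulforhodamine B assay, with a stated time of 48 h (a lower number here means a stronger inhibitor of growth, a higher number a weaker inhibitor of growth), compound 2 gives 100000 nM, level with compound 1 at 100000 nM. Compound 3 `CCCCCCCCCCCC[C@@H](O)[C@H]1CC[C@H]([C@H](O)CCCCCCCCCCNC(=O)c2ccsc2)O1` carries thiophen-3-yl in place of 1,3-thiazol-5-yl on a carbonyl carbon. Among the compounds with values here, the only measured step that bears on this is no change at the digits printed from compound 1 to compound 2 (within the scatter), a swap of the aromatic ring on that same carbonyl carbon. With that single precedent, no shift in this assay is anticipated. The expected step is no change at the digits printed from compound 2 to compound 3 (within the scatter), with no direction favoured. Compound 3 is expected at 100000 nM, within an estimated range of 35000 nM to 150000 nM.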

Compound 3, concentration for 50% growth inhibition: 1700 nM
Beside the measured number, compound 3's estimate is 59-fold (1.77 log units) above it, outside the stated range (below it).
By their numbers in this assay, from the lowest: compound 3; then compounds 1 and 2 (each within the scatter of the next).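

In this assay, the choice of aromatic ring on the carbonyl carbon turns out to matter: thiophen-3-yl gives a 59-fold lower number from compound 2 to compound 3 (1.77 log units; beyond the scatter) and a 59-fold lower number from compound 1 to compound 3 (1.77 log units; beyond the scatter) while the earlier ring swap gave only no change at the digits printed from compound 1 to compound 2 (within the scatter) at this position. This position therefore does not treat all five-membered aromatic rings alike. Nothing available explains this step. As far as these compounds go, whether thiophen-2-yl, phenyl or pyridin-3-yl on the same carbonyl carbon would give a similarly low number in this assay remains open, as does whether thiophen-3-yl would do so with a shorter chain.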